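Chain change on the shared core: compound 2 to compound 3

The source may hold more compounds than are shown below. What is called first, only, known or untested is meant among the compounds shown, and "the series" means these compounds.

Of the compounds shown here, two on a shared core have numbers so far. In a functional assay on MCF7 cells (Homo sapiens) for inhibition (a higher number here means a weaker inhibitor, a lower number a stronger inhibitor), compound 1 `C/C=C/C(C)=C/[C@@]1(C)SC(O)=CC1=O` gives 17.3 ug/mL and compound 2 `CC/C=C/C=C/[C@@]1(C)SC(O)=CC1=O` gives 16.9 ug/mL so the two lie within the scatter of each other and cannot be ranked. Compound 2 therefore stands level with compound 1 on the present numbers.

Compound 3 `CCCC/C=C/C=C/[C@@]1(C)SC(O)=CC1=O` keeps the core and alters only the chain of compound 2. The change is ethyl in place of hydrogen on a saturated chain carbon, two bonds along the chain from a double-bonded chain carbon with ethyl in place of hydrogen on a saturated chain carbon, two bonds along the chain from a double-bonded chain carbon. The same difference reads ethyl to butyl.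

For the measured compounds named here, no measured pair differs in this way alone, so no direct guide exists. Going by the values given here, the only indication is that compound 1 at 17.3 ug/mL and compound 2 at 16.9 ug/mL do not separate although their chains differ. The expected step of a 1.1-fold lower number from compound 2 to compound 3 (0.05 log units; within the scatter) is small, leaning slightly toward a lower number, and is not expected to go beyond the scatter.

In this assay the estimate for compound 3 is 15 ug/mL with an expected range from 6.5 ug/mL to 32 ug/mL and the measurement is still to come.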

Compound 3, half-maximal inhibitory concentration: 22.6 ug/mL
Compound 3: middle estimate off by 1.5-fold (0.18 log units), on the low side; the measured number falls inside the stated range.
By their numbers in this assay, from the lowest: compounds 2, 1 and 3 (each within the scatter of the next).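

In this assay, ethyl in place of hydrogen on a saturated chain carbon, two bonds along the chain from a double-bonded chain carbon, gives a 1.3-fold higher number from compound 2 to compound 3 (0.13 log units; within the scatter) and so cannot be told apart from repeat scatter. For the compounds shown here, this is the first measured pair that differs in one place only, so the position now has a direct reading that the earlier compounds could not give: the ethyl to butyl difference leaves the number unresolved from that of the shorter chain, and no trend with chain length can be drawn from this single step. Nothing measured alongside these numbers bears on this reading.

Going by these compounds, it remains open whether a longer chain than butyl, or a chain ending in an amine or a carboxylic acid, would produce a step beyond the scatter at this position. On these data alone, it also remains open whether the same ethyl for hydrogen difference would read the same way on the methyl-branched chain of compound 1.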